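Adding cyclopropylcarbonyl to compound 3

The compounds below may be only part of what the source reports. "The series", "measured", "known", "first", "only" and "open" are said of these compounds alone.

Measured in a functional assay on K562 cells (Homo sapiens) for inhibition, read by MTT assay, with a stated time of 48 h; on this read-out higher numbers stand for weaker inhibition and lower numbers for stronger inhibition:
- compound 1 `O=C(Nc1n[nH]c2cc(-c3cn([C@@H]4CN[C@H](C(=O)Nc5ccc(Cl)c(C(F)(F)F)c5)C4)nn3)ccc12)C1CC1` gives 5200 nM
- compound 2 `O=C(Nc1n[nH]c2cc(-c3cn([C@@H]4CN[C@H](C(=O)Nc5ccc(Cl)cc5Cl)C4)nn3)ccc12)C1CC1` gives 5340 nM
- compound 3 `Nc1n[nH]c2cc(-c3cn([C@@H]4CN[C@H](C(=O)Nc5ccc(Br)cc5)C4)nn3)ccc12` gives 10300 nM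

Compound 3 lies within the scatter of both compound 1 and compound 2, so the three values set no order. Compound 4 `O=C(Nc1n[nH]c2cc(-c3cn([C@@H]4CN[C@H](C(=O)Nc5ccc(Br)cc5)C4)nn3)ccc12)C1CC1` differs from compound 3 by cyclopropylcarbonyl in place of hydrogen on a nitrogen on an aromatic ring, which puts cyclopropylcarbonyl in place of hydrogen on a nitrogen on an aromatic ring. Going by the values given here, no measured step covers this change. Among the compounds with values here, the only step available, a 1.0-fold higher number from compound 1 to compound 2 (0.01 log units; within the scatter), lies at another place and bears on it only indirectly. Compound 1 and compound 2 already carry cyclopropylcarbonyl, and their values sit within the scatter of compound 3. No step beyond the scatter is therefore expected in this assay. The expected step is a 1.7-fold lower number from compound 3 to compound 4 (0.23 log units; within the scatter). Compound 4 is estimated at 6000 nM, with an expected range from 3000 nM to 11500 nM.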

Compound 4, half-maximal inhibitory concentration: 8080 nM
Estimate against measurement, compound 4: 1.3-fold (0.13 log units) below; the range from low to high includes it.
By their numbers in this assay, from the lowest: compounds 1, 2, 4 and 3 (each within the scatter of the next).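

Going by these compounds alone, at this nitrogen, this assay gives a 1.3-fold lower number from compound 3 to compound 4 (0.11 log units; within the scatter) for amino to (cyclopropylcarbonyl)amino, the first direct reading of this change, and the step stays within the scatter. With cyclopropylcarbonyl held in place, a 1.5-fold higher number from compound 2 to compound 4 (0.18 log units; within the scatter) and a 1.6-fold higher number from compound 1 to compound 4 (0.19 log units; within the scatter) for the changes to 4-bromophenyl, so these aryl groups are not set apart from one another. No measurement shown explains these results. As far as these compounds go, whether an acetyl group or a longer acyl chain on this nitrogen would give a step beyond the scatter remains open.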